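This account rests on a few compounds, and the source may have more. Where it says the series, first, only, none or still open, it means among the compounds named here.

In this series one core is kept and only the group on an oxygen on a saturated carbon is varied. Compound 1 `Cc1c(OC[C@@H](C)COc2ccc(C(=O)O)cc2F)ccc(C(=O)CC(C)(C)C)c1O` gives 1300 nM in an assay for positive allosteric modulation of metabotropic glutamate receptor 3 (Rattus norvegicus) (a higher number here means that more compound is needed for the effect, a lower number that less compound is needed), and compound 2 `Cc1c(OC[C@@H](C)COc2ccc(C(=O)O)c(Cl)c2)ccc(C(=O)CC(C)(C)C)c1O` gives 860 nM in this assay; the step of a 1.5-fold lower number from compound 1 to compound 2 (0.18 log units; within the scatter) stays within the scatter. Compound 3 `Cc1c(OC[C@@H](C)COc2ccc3c(c2)C(=O)NC3)ccc(C(=O)CC(C)(C)C)c1O` gives "not active" (no number reported) in this assay, so no number marks where it stands. Compound 4 `COc1ccccc1OC[C@H](C)COc1ccc(C(=O)CC(C)(C)C)c(O)c1C` differs from compound 3 in that (a group of 8 heavy atoms (7 carbon, 1 oxygen; one six-membered aromatic ring of carbon only) in place of a group of 10 heavy atoms (8 carbon, 1 nitrogen, 1 oxygen; one five-membered non-aromatic ring with 1 hetero atom, one six-membered aromatic ring of carbon only), on an oxygen on a saturated carbon). Going by the values given here, no measured step exchanges the group that enters here, and the single measured step concerns a different pair, so neither direction nor size of this step can be read from the data. Compound 4 is therefore expected, with a wide range, near 3000 nM, between 500 nM and 20000 nM.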

Compound 4, half-maximal effective concentration: "not active" (no number reported)
Compound 4: no number reported; no gap can be computed for the estimate.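

Compound 3 and compound 4 both come without a number, so no new step can be read from them, and nothing shown bears on this result. The compounds shown leave open how the 2-methoxyphenyl group compares with the other groups on this oxygen.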